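The source may hold more compounds than are shown below. What is called first, only, known or untested is meant among the compounds shown, and "the series" means these compounds.

Compound 1 `C/C(=C\c1cc(-c2cccnc2)co1)C(N)=O` and compound 2 `C/C(=C\c1cc(-c2ccc(C)nc2)co1)C(N)=O` share one core, compound 3 `C/C(=C\c1cc(-c2ccccc2)cs1)C(N)=O` and compound 4 `C/C(=C\c1cc(-c2ccccc2C)cs1)C(N)=O` share another, and the difference between the two cores is not broken down here. In a functional assay on T-24 cells (Homo sapiens) for cytotoxicity, read by CCK-8 assay, with a stated time of 24 h (on this read-out higher numbers stand for weaker inhibition and lower numbers for stronger inhibition), compound 1 gives > 50000 nM, which is a limit of the assay rather than a number. Compound 2 likewise gives only a limit, > 50000 nM. Compound 3 also gives only a limit, > 50000 nM. The change from compound 1 to compound 2 is methyl in place of hydrogen on an aromatic carbon, and its step is a step that the two limits leave unreadable from compound 1 to compound 2 because of the limit of > 50000 nM in this assay, at which 3 of the 3 values shown sit. The change from compound 3 to compound 4 is the same kind of change, (methyl in place of hydrogen on an aromatic carbon), though the place differs: on a six-membered aromatic ring with 1 nitrogen, next to the ring nitrogen, para to a large group in the first pair, on a six-membered aromatic ring of carbon only, ortho to a large group in the second. A step that the limit leaves unreadable from compound 3 to compound 4 is expected because the limit of > 50000 nM in this assay, at which 3 of the 3 values shown sit, leaves the earlier step unreadable. Compound 4 is therefore expected to give 80000 nM, most probably again only as a limit.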

Compound 4, half-maximal inhibitory concentration: > 50000 nM
Compound 4: a limit, no number (the forecaster's own chance of this, stated with the estimate: 85%); the middle value lies beyond the limit too.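

No step can be read from compound 3 to compound 4, because both values are only limits of the assay: the limit of > 50000 nM in this assay, at which 4 of the 4 values shown sit.

As far as these compounds go, what the methyl does to the cytotoxicity of compound 3 and compound 4 stays open.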